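The compounds below may be only part of what the source reports. "The series", "measured", "known", "first", "only" and "open" are said of these compounds alone.

Measured so far in a functional assay on HOS-TE85 cells (Homo sapiens) for inhibition, read by CCK-8 assay, with a stated time of 72 h; a higher number here means a weaker inhibitor, a lower number a stronger inhibitor:
compound 1 `COc1ccccc1N1C(=O)CSC1c1cc(F)cc(C(=O)O)c1`: > 1000 nM
compound 2 `COc1ccc(OC)c(N2C(=O)CSC2c2cccc(C(=O)NCCCCc3ccccc3)c2)c1`: > 1000 nM
compound 3 `CCOC(=O)c1sc(N2C(=O)CSC2c2cccc(C(=O)NCCCCn3cccn3)c2)nc1C`: 430 nM

Compound 1 reports only a limit in this assay, namely > 1000 nM. Compound 2 likewise sits at a limit in this assay, > 1000 nM. Its place in the series is therefore given only by the limit of > 1000 nM in this assay, at which 2 of the 3 values shown sit: compound 2 stands together with compound 1 there, and no number separates the two. Going by the values given here, compound 3 is the one compound with a number, giving 430 nM in this assay. Against compounds 1 and 2 nothing further can be read, since only one side of each pair is a number.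

Compound 4 `O=C(NCCCCc1ccccc1)c1cccc(C2SCC(=O)N2c2ccc(C3CC3)cc2)c1` is still to be measured in this assay. It differs from compound 2 in one place: 4-cyclopropylphenyl in place of 2,5-dimethoxyphenyl on an amide-type nitrogen in a ring. No step between two measured compounds is shown, so the size of this step has no counterpart in the series. Expectation: a step not clearly beyond the scatter, and with the starting value a limit, the outcome may again be a limit. Compound 4 is expected at 1500 nM, within 300 nM to 6000 nM. That estimate means an expected step that the limit leaves unreadable from compound 2 to compound 4, not a change beyond the scatter.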

Compound 4, half-maximal inhibitory concentration: 217 nM
The estimate for compound 4 lay 6.9-fold (0.84 log units) above the measured number; measured number below the stated range.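

In this assay, going by these compounds alone, 4-cyclopropylphenyl in place of 2,5-dimethoxyphenyl on the amide-type nitrogen in a ring gives an at least 4.6-fold lower number from compound 2 to compound 4 (0.66 log units; beyond the scatter), the first step that can be read across a single change. Within the data shown here, with the rest of the structure shared, the group on this nitrogen alone is enough to bring a compound from a limit to a number, a point the earlier compounds could not show. Compound 2 gives only a limit, > 1000 nM, and the true size of the step stays unknown because one end of it is not a number: the limit of > 1000 nM in this assay, at which 2 of the 4 values shown sit.

The swap removes two hydrogen-bond acceptors and adds a three-membered carbon ring in one move, so the result does not separate the loss of the two methoxy groups from the gain of the cyclopropyl group. On these data alone, a plain phenyl, a 4-isopropylphenyl or a 4-aminophenyl on this nitrogen would bear on that question, and whether the same change holds with a different amide chain or with a carboxylic acid in its place also remains open.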